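The compounds below may be only part of what the source reports. "The series", "measured", "known", "first", "only" and "open" are said of these compounds alone.

Measured so far:
compound 1, `Oc1ccccc1-c1cc(-c2cccc(F)c2)cc(-c2ccccc2O)n1`: > 50000 nM
compound 2, `Oc1ccccc1-c1cc(-c2ccc(F)cc2)cc(-c2ccccc2O)n1`: > 50000 nM
compound 3, `Oc1ccc(-c2cc(-c3cccc(F)c3)cc(-c3cccc(O)c3)n2)cc1`: 3510 nM

All three were tested in a functional assay on T47D cells (Homo sapiens) for inhibition; on this read-out higher numbers stand for weaker inhibition and lower numbers for stronger inhibition. In this assay compound 1 gives > 50000 nM, which is a limit of the assay and not a number. In this assay compound 2 gives > 50000 nM, again a limit and not a number. Compound 3 is the only one of the three with a measured number: in this assay compound 3 gives 3510 nM.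

Compound 1 and compound 2 differ in one place: 4-fluorophenyl in place of 3-fluorophenyl on an aromatic carbon. Both of their values sit at the limit of > 50000 nM in this assay, at which 2 of the 3 values shown sit, and the step that the two limits leave unreadable from compound 1 to compound 2 is not readable.

Compound 4, `Oc1ccc(-c2cc(-c3ccc(F)cc3)cc(-c3cccc(O)c3)n2)cc1`, is not yet measured. It differs from compound 3 in one place: 4-fluorophenyl in place of 3-fluorophenyl on an aromatic carbon. This is the same kind of change as that from compound 1 to compound 2, but not the same: in compound 1 the changed position is meta to two 2-hydroxyphenyl groups, whereas in compound 3 it is meta to a 3-hydroxyphenyl group and meta to a 4-hydroxyphenyl group. The difference between the two cores, compound 1 against compound 3, is not broken down here.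

Going by the values given here, the one earlier measurement of this change gives no readable size, so the expectation for compound 4 rests on compound 3 alone. With compound 3 at 3510 nM as the only anchor, the expected size of the step is a 1.0-fold lower number from compound 3 to compound 4 (0.00 log units; within the scatter), within the usual scatter. In this assay compound 4 is estimated at 3500 nM, most likely between 1200 nM and 12000 nM.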

Compound 4, half-maximal inhibitory concentration: 5000 nM
Estimate against measurement, compound 4: 1.4-fold (0.15 log units) below; the measured number falls inside the stated range.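

In this assay, putting 4-fluorophenyl in place of 3-fluorophenyl on the core of compound 3 gives a 1.4-fold higher number from compound 3 to compound 4 (0.15 log units; within the scatter), so on this core the two fluorophenyl groups cannot be told apart. On the core of compound 1 the same change cannot be read, because compound 1 and compound 2 both stand at a limit of the assay and not at a number: the limit of > 50000 nM in this assay, at which 2 of the 4 values shown sit. Going by these compounds alone, the series therefore offers only one readable step for this change, which shows what it does on one core but not that it would behave the same way on another, since there is no second size to set beside the first.

The compounds shown leave open whether any other group at this position, such as an amine or a carboxylic acid on the phenyl ring in place of the fluorine, would shift the number beyond the usual scatter. Within the data shown here, they also leave open which feature separates the two cores, as the core of compound 1 and the core of compound 3 differ in more than one place and no single step between them can be read here.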